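Swapping Cyclobutyl for 2-Fluorocyclopropyl on the Shared Core

This account rests on a few compounds, and the source may have more. Where it says the series, first, only, none or still open, it means among the compounds named here.

Three amides of one shared core have been measured in an assay on CHO cells for displacement of a labelled ligand from Neuronal acetylcholine receptor; alpha3/alpha6/beta2/beta3 (Homo sapiens), read by scintillation counting; a higher number here means a weaker inhibitor, a lower number a stronger inhibitor. Compound 1 `CCC(=O)N1CC2CC(C1)N2` gives 190 nM, compound 2 `CC(C)C(=O)N1CC2CC(C1)N2` gives 580 nM, and compound 3 `O=C(C1CCC1)N1CC2CC(C1)N2` gives 240 nM. Compound 3 thus stands second highest of the three, close to compound 1 and clearly apart from compound 2, as the steps of a 1.3-fold higher number from compound 1 to compound 3 (0.10 log units; within the scatter) and a 2.4-fold lower number from compound 2 to compound 3 (0.38 log units; beyond the scatter) show. Compound 4 `O=C([C@@H]1C[C@@H]1F)N1CC2CC(C1)N2` differs from compound 3 only in 2-fluorocyclopropyl in place of cyclobutyl on a carbonyl carbon. The measured steps on this carbonyl carbon are small or modest, so no step beyond the scatter is expected in this assay, with a 1.0-fold higher number from compound 3 to compound 4 (0.02 log units; within the scatter) as the estimated change. Compound 4 is therefore expected to give about 250 nM in this assay, within a range from 100 nM to 650 nM.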

Compound 4, inhibition constant: 55 nM
Estimate against measurement, compound 4: 4.5-fold (0.66 log units) above; measured number below the stated range.
By their numbers in this assay, from the lowest: compound 4; then compounds 1 and 3 (each within the scatter of the next); then compound 2.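

In this assay, for the compounds shown here, the group on this carbonyl carbon turns out able to lower the number markedly: 2-fluorocyclopropyl gives a 4.4-fold lower number from compound 3 to compound 4 (0.64 log units; beyond the scatter) and a 3.5-fold lower number from compound 1 to compound 4 (0.54 log units; beyond the scatter) and an 11-fold lower number from compound 2 to compound 4 (1.02 log units; beyond the scatter) in the only large step here, which makes compound 4 the strongest of the four. Cyclobutyl and 2-fluorocyclopropyl hold the same count of heavy atoms, so that count alone does not set the number. Nothing shown here accounts for the drop.

From the compounds shown here alone, what plain cyclopropyl or the mirror-image 2-fluorocyclopropyl would give on this carbonyl carbon stays open, and with it whether the lower number goes with the fluorine, the three-membered ring or the stereocentres.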